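Same Change, Two Cores, One Open Question

A few compounds are considered here, and "the series" means these few. Any claim that something is new, unique, unknown or untested is made for them only; others in the source may bear on it.

Compound 1 `C=C(Br)C(=O)Nc1ccc(/C=C2\SC(=O)N(Cc3ccc(C)cc3)C2=O)cc1`: 6100 nM
Compound 2 `C=C(Br)C(=O)Nc1ccc(/C=C2\SC(=O)N(C)C2=O)cc1`: 750 nM
Compound 3 `Cc1ccc(CN2C(=O)S/C(=C\c3ccc(N)cc3)C2=O)cc1`: a limit of the assay, > 250000 nM

All three were tested in a functional assay on FM3A cells (Mus musculus) for cytotoxicity, read by cell counting, with a stated time of 2 days; on this read-out lower numbers stand for stronger inhibition and higher numbers for weaker inhibition. The change from compound 1 to compound 2, (hydrogen in place of 4-methylphenyl on a saturated chain carbon bound to an amide-type nitrogen in a ring), gave an 8.1-fold lower number from compound 1 to compound 2 (0.91 log units; beyond the scatter). The core of compound 3 differs from that of compound 1 by hydrogen in place of (1-bromoethenyl)carbonyl on a nitrogen on an aromatic ring, and that change gave an at least 40-fold higher number from compound 1 to compound 3 (1.61 log units; beyond the scatter).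

Compound 4 `CN1C(=O)S/C(=C\c2ccc(N)cc2)C1=O` carries the same change that turned compound 1 into compound 2, (hydrogen in place of 4-methylphenyl on a saturated chain carbon bound to an amide-type nitrogen in a ring), at the same place, but on the core of compound 3. Because compound 3 sits at the limit of > 250000 nM in this assay, at which 1 of the 3 values shown sits, the earlier step cannot be carried over as a number. The expected step is an at least 1.2-fold lower number from compound 3 to compound 4 (0.09 log units; that floor lies within the scatter), with wide uncertainty. Compound 4 is expected near 200000 nM, between 30000 nM and 1000000 nM, and may again appear only as a limit.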

Compound 4, half-maximal inhibitory concentration: 107000 nM
Compound 4: the middle estimate sits 1.9-fold (0.27 log units) above what was measured; the measured number falls inside the stated range.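

In this assay, hydrogen in place of 4-methylphenyl gave an at least 2.3-fold lower number from compound 3 to compound 4 (0.36 log units; beyond the scatter), the same direction as on the core of compound 1: the same change on two cores in this assay, an 8.1-fold lower number (0.91 log units; beyond the scatter) from compound 1 to compound 2 and an at least 2.3-fold lower number (0.36 log units; beyond the scatter) from compound 3 to compound 4; the limit leaves it open whether they differ. For compound 3, > 250000 nM is a limit of the assay, not a number. The direction of this change therefore carried from one core to the other, but its size cannot be compared, and the same holds for hydrogen in place of (1-bromoethenyl)carbonyl, which gave a 140-fold higher number from compound 2 to compound 4 (2.15 log units; beyond the scatter): the same change on two cores in this assay, an at least 40-fold higher number (1.61 log units; beyond the scatter) from compound 1 to compound 3 and a 140-fold higher number (2.15 log units; beyond the scatter) from compound 2 to compound 4; the limit leaves it open whether they differ.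

The compounds shown leave open how a longer chain such as propyl, or an amine, would behave at the same place. They also leave open whether acetyl in place of (1-bromoethenyl)carbonyl would follow compound 2 or compound 4.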